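Swapping Methyl for Trifluoromethyl on the Aromatic Ring

A few compounds are considered here, and "the series" means these few. Any claim that something is new, unique, unknown or untested is made for them only; others in the source may bear on it.

Two measured compounds share a core and differ in two places. Compound 1 `COCC(C(=O)N1CCN(c2cccc(C(F)(F)F)c2)CC1)N1C(=O)CCC1=O` carries a trifluoromethyl group on its aromatic ring, and in a functional assay on the whole organism (strain Swiss) with Mus musculus as the target, in the maximal electroshock model, with a stated time of 1 h, at a dose of 300 mg/kg by the intraperitoneal route (on this read-out lower numbers stand for a weaker effect and higher numbers for a stronger effect at the one dose given), compound 1 gives 100%. Compound 2 `CCC(C(=O)N1CCN(c2cccc(C)c2)CC1)N1C(=O)CCC1=O` carries a methyl group there, and in this assay compound 2 gives 75%. Compound 2 therefore stands lowest of the two numbers, with compound 1 above it by a gap that goes beyond the scatter. Going by the values given here, no pair of measured compounds differs in a single place, so these two values show only that the trifluoromethyl-bearing compound 1 scores higher overall.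

Compound 3 `CCC(C(=O)N1CCN(c2cccc(C(F)(F)F)c2)CC1)N1C(=O)CCC1=O` is not yet measured. It differs from compound 2 in one place: trifluoromethyl in place of methyl on an aromatic carbon. The change sits on an aromatic carbon of a six-membered aromatic ring of carbon only, meta to a large group. Because compound 1 reaches 100% with the same trifluoromethyl group, compound 3 is expected to move upward by a number 17 percentage points higher from compound 2 to compound 3 (beyond the scatter), a step beyond the scatter. In this assay compound 3 is estimated at 92%, with a range from 75% to 100%.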

Compound 3, a percentage reported as activity, at one dose (the size of the read-out at that dose, not a potency): 100%
Compound 3: middle estimate off by 8 percentage points, on the low side; the range from low to high includes it.
By their numbers in this assay, from the lowest: compound 2; then compounds 1 and 3 (each within the scatter of the next).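

In this assay, going by these compounds alone, trifluoromethyl in place of methyl on an aromatic carbon, meta to a large group, gives a number 25 percentage points higher from compound 2 to compound 3 (beyond the scatter), and this is the first comparison in which only that group changes, so the step can be assigned to this swap alone. The second single change, methyl in place of methoxy on a saturated chain carbon, gives no change at the digits printed from compound 1 to compound 3 (within the scatter), so this chain change leaves no visible mark on the read-out while trifluoromethyl sits on the ring, although both values lie at the top of a percentage scale, where any further gain could not show. No measurement shown here explains the step on the ring.

On these data alone, whether a chlorine or a nitrile on that aromatic carbon would match trifluoromethyl remains open, as does the effect of a longer chain or an amine on the saturated chain carbon. As far as these compounds go, the read-out comes from one dose only, so how compound 1 and compound 3 would compare at lower doses also stays unknown.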